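Replacing the Nitro Group of Compound 1

The source may report more compounds than this note shows. Statements on the series, on what has been measured and on what is new or still open speak of the compounds shown alone.

Compound 1 `O=[N+]([O-])c1ccc(-c2nc3cc(C(F)(F)F)ccc3[nH]2)cc1`: 6000 nM
Compound 2 `O=[N+]([O-])c1ccc(-c2nc3cc(C(F)(F)F)ccc3[nH]2)c([N+](=O)[O-])c1`: 9000 nM
Compound 3 `Cn1c(-c2ccc([N+](=O)[O-])cc2)nc2cc(C(F)(F)F)ccc21`: >= 100000 nM

These readings come from an ADME assay on MT4 cells (Homo sapiens) for cytotoxicity, read by MTT assay, with a stated time of 96 h; on this read-out higher numbers stand for lower toxicity in this test and lower numbers for higher toxicity in this test. Compound 1 sits at the low, more toxic end of these readings alongside compound 2, and the two lie within the scatter of each other. For compound 3 , >= 100000 nM is a limit of the assay and not a number.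

Compound 4 `O=C(O)CCC(=O)Nc1ccc(-c2nc3cc(C(F)(F)F)ccc3[nH]2)cc1` keeps the core of compound 1 but carries ((2-carboxyethyl)carbonyl)amino in place of nitro on an aromatic carbon.

Two measured steps offer guidance, and neither replaces the nitro group itself. Adding a second nitro group on an aromatic carbon gave a 1.5-fold higher number from compound 1 to compound 2 (0.18 log units; within the scatter), so that change made no clear difference. Placing methyl on an aromatic nitrogen gave an at least 16-fold higher number from compound 1 to compound 3 (1.22 log units; beyond the scatter), a large step, but at a different place in the molecule. The evidence is therefore thin. Going by the values given here, compound 1 has little room to fall, given its value of 6000 nM, and the one large step ran upward, so a moderate rise is the cautious expectation.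

The expected change is a 5.8-fold higher number from compound 1 to compound 4 (0.77 log units; beyond the scatter). For compound 4 the estimated value is 35000 nM, with an expected range of 9000 nM to 100000 nM.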

Compound 4, half-maximal cytotoxic concentration: > 100000 nM
Compound 4 gave a limit, no number; the forecaster's own chance of this, stated with the estimate: 40%; middle value at least 2.8-fold (0.45 log units) away from the limit.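

The nitro position itself turns out to be open to change: in this assay, exchanging nitro for ((2-carboxyethyl)carbonyl)amino gave an at least 16-fold higher number from compound 1 to compound 4 (1.22 log units; beyond the scatter). Among the earlier compounds, the only large step came from methyl on an aromatic nitrogen, while adding a second nitro on an aromatic carbon gave a 1.5-fold higher number from compound 1 to compound 2 (0.18 log units; within the scatter), so this is the first large step shown at an aromatic carbon, here on the six-membered ring and para to a large group. In this assay compound 4 gives > 100000 nM, which is a limit of the assay and not a number, so the full size of its step cannot be read, and the reading stands as: the limit of > 100000 nM in this assay, at which 1 of the 4 values shown sits.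

The entering group brings a longer chain and a carboxylic acid at the same time, so the compounds shown cannot say which part of it goes with the step. An amine in place of nitro, or the same chain ending in a methyl ester, would help to separate those parts.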